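This account rests on a few compounds, and the source may have more. Where it says the series, first, only, none or still open, it means among the compounds named here.

Two compounds carry numbers in an assay on HEK293 cells for displacement of a labelled ligand from adenosine receptor A2b (Homo sapiens), with a stated time of 30 min; on this read-out higher numbers stand for weaker inhibition and lower numbers for stronger inhibition. Compound 1 `CCOC(=O)C1=C(C)NC(=O)CC1c1ccco1` gives 2540 nM, and compound 2 `CCOC(=O)C1=C(C)Nc2nccn2C1c1ccco1` gives 108 nM, the lower of the two numbers, with compound 1 standing beyond the scatter above it. Compound 3 `CC1=C(C(=O)OC(C)C)C(c2ccco2)n2ccnc2N1` is not yet measured in this assay. It differs from compound 2 by methyl in place of hydrogen on a saturated chain carbon bound to an oxygen next to a carbonyl group and a saturated chain carbon. Among the compounds with values here, no measured pair here shows what such a change does, so the expected step of a 1.4-fold higher number from compound 2 to compound 3 (0.14 log units; within the scatter) is taken as small, if anything toward a slightly higher number, and not beyond the scatter. Compound 3 is expected near 150 nM in this assay, within 50 nM to 500 nM.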

Compound 3, inhibition constant: 85.6 nM
Estimate against measurement, compound 3: 1.8-fold (0.24 log units) above; the measured number falls inside the stated range.
By their numbers in this assay, from the lowest: compounds 3 and 2 (each within the scatter of the next); then compound 1.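

In this assay, the change from ethoxycarbonyl to isopropoxycarbonyl gives a 1.3-fold lower number from compound 2 to compound 3 (0.10 log units; within the scatter), so the added methyl on this saturated chain carbon leaves the two compounds indistinguishable. Within the data shown here, this is the first reading at this position, and it shows that the branched isopropoxy group is tolerated here without a shift beyond the scatter. No supporting data bear on why this is so. As far as these compounds go, whether a longer chain on the oxygen, or a carboxylic acid or an amide in place of the ester, would also be tolerated remains open.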